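Compound 3 Follows a Large Step in Growth Inhibition

The source may hold more compounds than are shown below. What is called first, only, known or untested is meant among the compounds shown, and "the series" means these compounds.

In a functional assay on SK-OV-3 cells (Homo sapiens) for cytotoxicity (on this read-out higher numbers stand for weaker inhibition of growth and lower numbers for stronger inhibition of growth), compound 2 (`CSc1ccc(C2=C(c3ccc(F)c(F)c3)C(=O)N3CCCC3C2)cc1`) gives 100 nM, the lower of the two numbers, while compound 1 (`COc1ccc(C2=C(c3ccc(SC)cc3)CC3CCCN3C2=O)cc1C`) gives 15000 nM. Compound 3 (`CSc1ccc(C2=C(c3ccc(C)c(C)c3)C(=O)N3CCCC3C2)cc1`) differs from compound 2 in one place: 3,4-dimethylphenyl in place of 3,4-difluorophenyl on a double-bonded ring carbon, with 3,4-dimethylphenyl in place of 3,4-difluorophenyl. Among the measured compounds shown here, the only measured step, a 150-fold lower number from compound 1 to compound 2 (2.18 log units; beyond the scatter), is large and replaced a 4-methoxy-3-methylphenyl group on that same carbon. Only part of that step is expected to return, giving an estimated 4.0-fold higher number from compound 2 to compound 3 (0.60 log units; beyond the scatter). In this assay the expected value of compound 3 is 400 nM, within a range of 80 nM to 3000 nM.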

Compound 3, concentration for 50% growth inhibition: 300 nM
Compound 3: the middle estimate sits 1.3-fold (0.12 log units) above what was measured; the range from low to high includes it.
By their numbers in this assay, from the lowest: compound 2; then compound 3; then compound 1.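

In this assay, the double-bonded ring carbon accepts 3,4-dimethylphenyl as well as 3,4-difluorophenyl at a modest cost, with a 3.0-fold higher number from compound 2 to compound 3 (0.48 log units; beyond the scatter). Methyl in place of methoxy on the aromatic ring alone gives a 50-fold lower number from compound 1 to compound 3 (1.70 log units; beyond the scatter), so most of the earlier large step goes with that single swap, and fluorine is not needed for a low number. Nothing available explains either step. Still open, from the compounds shown here alone, is how a hydroxyl, an ethoxy or an amine would read in place of that methyl. Also open, going by these compounds, is whether a single methyl or chlorine on the phenyl ring would hold the number of compound 3.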